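The source may hold more compounds than are shown below. What is called first, only, known or untested is meant among the compounds shown, and "the series" means these compounds.

Measured compounds:
- compound 1 `CCN1CCN(CCCn2cnc3c(N4CCN(CC)CC4)nc(NCc4ccccc4)nc32)CC1` gives 140 nM
- compound 2 `CN(C)Cc1ccc(CNc2nc(N3CCN(C4CCCC4)CC3)c3ncn(CCCN4CCCC4)c3n2)cc1` gives 7 nM

In an assay on HEK293 cells for antagonist activity at Toll-like receptor 9 (Homo sapiens), read by spectrophotometry (a lower number here means a stronger inhibitor, a higher number a weaker inhibitor), compound 1 stands at the higher of the two numbers; compound 2 gives the lower number, and the gap between them lies well beyond the scatter of repeated measurements. The two compounds differ in several places at once, so the gap cannot be assigned to any single change.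

Compound 3 `CCN1CCN(CCCn2cnc3c(N4CCN(CC)CC4)nc(NCc4ccc(OC)cc4)nc32)CC1` is the unmeasured compound. It is obtained from compound 1 by one change: methoxy in place of hydrogen on an aromatic carbon. Among the compounds with values here, no pair of measured compounds differs only in this way, so the step has no direct precedent here. Compound 3 is expected to move toward a somewhat lower number, with the step of a 1.8-fold lower number from compound 1 to compound 3 (0.24 log units; within the scatter) estimated as modest and plausibly within the scatter. For compound 3 the estimated value in this assay is 80 nM, with a range from 30 nM to 250 nM.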

Compound 3, half-maximal inhibitory concentration: 200 nM
For compound 3 the middle estimate is 2.5-fold (0.40 log units) below the measured one; the measured number falls inside the stated range.
By their numbers in this assay, from the lowest: compound 2; then compounds 1 and 3 (each within the scatter of the next).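

In this assay, methoxy in place of hydrogen on an aromatic carbon, para to a large group, gives a 1.4-fold higher number from compound 1 to compound 3 (0.15 log units; within the scatter). Within the data shown here, this is the first step in the set that changes one place only, and it places compound 1 and compound 3 within the scatter of each other, so at this position the benzylamino and (4-methoxybenzyl)amino compounds cannot be told apart in this assay. No measurement at hand accounts for this result.

From the compounds shown here alone, whether this position would read the same with a carboxylic acid or a longer alkoxy chain such as ethoxy remains open, as does the effect of methoxy on other carbons of the ring. The compounds shown also leave open which of the differences between compound 1 and compound 2 carries the gap between them.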